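The source may report more compounds than this note shows. Statements on the series, on what has been measured and on what is new or still open speak of the compounds shown alone.

For the measured compounds named here, in an ADME assay on Raji cells (Homo sapiens) for cytotoxicity, with a stated time of 72 h (a higher number here means that more compound is needed for the effect, a lower number that less compound is needed), compound 3 `COC(=O)c1ccc(NC(=O)Nc2cc(C)nc3ccccc23)cc1` gives 17000 nM, the only actual number so far. Compound 1 `CC(=O)c1ccc(NC(=O)Nc2cc(C)nc3ccccc23)cc1` reads > 25000 nM, which is a limit. Compound 2 `Cc1cc(NC(=O)Nc2ccc(F)cc2)c2ccccc2n1` reads > 25000 nM, also a limit. Compound 4 `Cc1cc(NC(=O)Nc2ccc(C(N)=O)cc2)c2ccccc2n1` carries amino in place of methoxy on a carbonyl carbon. Going by the values given here, two measured steps bear on this, each a floor set by a limit and within the scatter: an at least 1.4-fold lower number from compound 1 to compound 3 (0.16 log units; that floor lies within the scatter) at that same carbonyl carbon, and an at least 1.4-fold lower number from compound 2 to compound 3 (0.16 log units; that floor lies within the scatter) for the whole group. Neither fixes a real size. Starting from compound 3 at 17000 nM, no step beyond the scatter is expected in this assay. A limit reading for compound 4 is possible. The expected step is a 1.4-fold higher number from compound 3 to compound 4 (0.15 log units; within the scatter). Compound 4 is estimated at 24000 nM, with an expected range of 13000 nM to 40000 nM.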

Compound 4, half-maximal effective concentration: > 25000 nM
Compound 4 was reported as a limit; the forecaster's own chance of this, stated with the estimate: 65%; at least 1.0-fold (0.01 log units) between middle value and limit.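

In this assay, amino in place of methoxy on a carbonyl carbon gives an at least 1.4-fold higher number from compound 3 to compound 4 (0.16 log units; that floor lies within the scatter), so this floor points the same way as the other readings but does not separate the two groups. For the compounds shown here, with methyl in compound 1 and amino in compound 4 both reported as limits, methoxy in compound 3 is the only group on this carbonyl carbon with an actual number. The steps from compound 1 and compound 2 to compound 4 cannot be read, and the series is bunched at one ceiling: the limit of > 25000 nM in this assay, at which 3 of the 4 values shown sit.

Going by these compounds, the real size of any step at this position remains open. So does whether a carboxylic acid or a longer ester chain there would give an actual number.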